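The compounds below may be only part of what the source reports. "The series", "measured", "known", "first", "only" and "open" are said of these compounds alone.

Measured compounds:
compound 1, `CC(C)(C)Cc1csc(N)c1C(=O)c1ccc(Cl)cc1`: 5%
compound 2, `CC(C)(C)Cc1c(-c2ccncc2)sc(N)c1C(=O)c1ccc(Cl)cc1`: 6%

In an assay on CHO cells for displacement of a labelled ligand from adenosine receptor A3 (Homo sapiens), read by scintillation counting, tested at 10 uM (a higher number here means more inhibition at the concentration tested (going by the name of the read-out), a lower number less inhibition), compound 1 gives 5%, and compound 2 gives 6%. For the measured compounds named here, the only step between measured compounds is a number 1 percentage points higher from compound 1 to compound 2 (within the scatter), and it shows no effect beyond the scatter. Compound 2 thus stands highest of the two numbers, but its nearest neighbour is compound 1 within the scatter, so no order can be read between them; both sit low in this assay.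

Compound 3, `CC(C)c1ccc(-c2sc(N)c(C(=O)c3ccc(Cl)cc3)c2CC(C)(C)C)cc1`, differs from compound 2 in one place: 4-isopropylphenyl in place of pyridin-4-yl on an aromatic carbon. Going by the values given here, no measured step addresses an exchange of this kind; the one step known only shows that adding pyridin-4-yl at this position left the read-out unchanged within the scatter. There is therefore no basis for expecting a move beyond the scatter in this assay, and the working expectation is a step of about a number 2 percentage points higher from compound 2 to compound 3 (within the scatter) from compound 2 to compound 3. For compound 3 the estimated value in this assay is 8%, with an expected range from 0% to 25%.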

Compound 3, a percentage reported as inhibition, at one concentration (the size of the read-out at that concentration, not a potency): 1%
Estimate against measurement, compound 3: 7 percentage points above; measured number inside the range.
By their numbers in this assay, from the lowest: compounds 3, 1 and 2 (each within the scatter of the next).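

In this assay, 4-isopropylphenyl in place of pyridin-4-yl gives a number 5 percentage points lower from compound 2 to compound 3 (within the scatter), and the same group in place of hydrogen gives a number 4 percentage points lower from compound 1 to compound 3 (within the scatter). The aromatic carbon next to the ring sulfur has therefore now carried hydrogen, a six-membered aromatic ring with 1 hetero atom and a six-membered aromatic ring of carbon only, and neither the loss of the ring nitrogen nor the move from 6 to 9 heavy atoms separates these compounds beyond the scatter at this single concentration. No measurement on hand offers an explanation for this flat result, and none is needed to read it as it stands.

The three compounds give no step beyond the scatter, so they do not show whether any group on this carbon can change the read-out, for example a carboxylic acid, a piperazine or a longer chain ending in an amine. Also open, as far as these compounds go, is whether changes elsewhere on the shared core, such as a shorter chain in place of the neopentyl group or another group in place of the amino group, would move the number in this assay.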